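The source may report more compounds than this note shows. Statements on the series, on what has been measured and on what is new or still open speak of the compounds shown alone.

Compound 1 `O=C(CI)NCCCCC(=O)NCCCCCCNc1ncnc2c1ncn2[C@@H]1O[C@H](COP(=O)(O)OP(=O)(O)OP(=O)(O)O)[C@@H](O)[C@H]1O`: 0%
Compound 2 `CN(CCCCN(C)c1ncnc2c1ncn2[C@@H]1O[C@H](COP(=O)(O)OP(=O)(O)OP(=O)(O)O)[C@@H](O)[C@H]1O)C(=O)CCCNC(=O)CI`: 0%

Both were tested in an assay on isolated protein for inhibition of hexokinase-2 (Rattus norvegicus), with a stated time of 6 h, tested at 10 mM; a lower number here means less inhibition, a higher number more inhibition at the concentration tested (going by the name of the read-out). Compound 1 gives 0% there, and compound 2 gives 0%; the two values lie within the scatter of each other, so compound 1 stands level with compound 2 and neither shows inhibition at the concentration tested.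

Compound 3 `O=C(CI)NCCCC(=O)NCCCCCCNc1ncnc2c1ncn2[C@@H]1O[C@H](COP(=O)(O)OP(=O)(O)OP(=O)(O)O)[C@@H](O)[C@H]1O` has not yet been measured. It differs from compound 1 in one place: ((iodomethyl)carbonyl)amino in place of (((iodomethyl)carbonyl)amino)methyl on a saturated chain carbon, three bonds along the chain from a carbonyl carbon. Going by the values given here, no step between measured compounds is known, so the expectation rests on the two values alone, which both show no inhibition. Compound 3 is expected to give 0%, with a range from 0% to 10%. The expected step is no change at the digits printed from compound 1 to compound 3 (within the scatter), none beyond the scatter.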

Compound 3, a percentage reported as inhibition, at one concentration (the size of the read-out at that concentration, not a potency): 0%
For compound 3 middle estimate and measured number coincide at the digits printed, within the range that was stated.
By their numbers in this assay, from the lowest: compounds 1, 2 and 3 (each within the scatter of the next).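

In this assay the step of no change at the digits printed from compound 1 to compound 3 (within the scatter) comes from putting ((iodomethyl)carbonyl)amino in place of (((iodomethyl)carbonyl)amino)methyl on a saturated chain carbon, three bonds along the chain from a carbonyl carbon. Removing this one chain carbon therefore brings out no inhibition at the concentration tested, so the two chain lengths cannot be told apart here. Nothing measured offers an explanation for this reading. As far as these compounds go, whether a longer chain at this place, or an amine or a carboxylic acid in place of the ((iodomethyl)carbonyl)amino group, would give any inhibition remains open.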